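Methyl added beside the indole nitrogen: compound 4 from compound 3

The source may hold more compounds than are shown below. What is called first, only, known or untested is meant among the compounds shown, and "the series" means these compounds.

Of the compounds shown here, three have been tested in a functional assay on the whole organism (strain Wistar Albino) for inhibition, with Rattus norvegicus as the target, read by paw edema, with a stated time of 3 h, at a dose of 20 mg/kg; on this read-out higher numbers stand for more inhibition at the one dose given (going by the name of the read-out) and lower numbers for less inhibition. Compound 1 `Cc1occc1-c1nnc2sc(-c3cc(O)nc(O)c3)nn12` gives 16.5% in this assay. Compound 2 `COc1ccc(Cc2nnc3sc(-c4ccnc(Cl)c4)nn23)cc1OC` gives 22.5%. Compound 3 `COc1ccc2[nH]cc(Cc3nn4c(Cc5ccc(OC)c(OC)c5)nnc4s3)c2c1` gives 19.1%. Compound 3 sits among the other two numbers: the gap to compound 1 and the gap to compound 2 both fall within the scatter of repeated measurements, so the three results cannot be told apart on the data shown, and no pattern of structure against inhibition can be drawn from them.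

Compound 4 `COc1ccc2[nH]c(C)c(Cc3nn4c(Cc5ccc(OC)c(OC)c5)nnc4s3)c2c1` is the next member. It differs from compound 3 in one place: methyl in place of hydrogen on an aromatic carbon. Among the measured compounds shown here, a single methyl is a small addition, and with no measured pair showing any step beyond the scatter, there is no basis for expecting a change in either direction beyond that scatter in this assay. The estimated step of a number 0.9 percentage points higher from compound 3 to compound 4 (within the scatter) is therefore expected to stay within the scatter. For compound 4 the expected result is 20%, with a likely range from 9% to 31%.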

Compound 4, a percentage reported as inhibition, in the whole organism at one dose (the size of the read-out at that dose, not a potency): 21.4%
Compound 4: the middle estimate sits 1.4 percentage points below what was measured; the range from low to high includes it.
By their numbers in this assay, from the lowest: compounds 1, 3, 4 and 2 (each within the scatter of the next).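

In this assay, among the compounds shown here, this is the first pair that differs in one place, and it gives a number 2.3 percentage points higher from compound 3 to compound 4 (within the scatter). Methyl in place of hydrogen on an aromatic carbon, next to the ring nitrogen and next to the ring atom that bears a large group, therefore leaves inhibition at this dose indistinguishable from that of the unsubstituted parent. The position accepts this one added carbon without a step that can be told from the scatter, though a single pair sets no trend. No supporting measurement bears on this result.

From the compounds shown here alone, whether an ethyl chain, an amine or a carboxylic acid at the same carbon would give a step beyond the scatter remains open. Going by these compounds, with one dose and one time, any difference in potency between compound 3 and compound 4 also remains open.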